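The compounds below may be only part of what the source reports. "The series", "measured", "known", "first", "only" and "open" are said of these compounds alone.

Measured so far in an ADME assay on RAW264.7 cells (Mus musculus) for cytotoxicity, read by MTT assay, with a stated time of 24 h; a higher number here means that more compound is tolerated, a lower number that less compound is tolerated:
compound 1 `Cc1cccc(C2CC(c3ccc(Cl)c(Cl)c3)=NN2C2=NC(=O)CS2)c1` gives 204000 nM
compound 2 `COc1ccc(C2CC(c3ccc(C)c(C)c3)=NN2C2=NC(=O)CS2)cc1` gives 387000 nM
compound 3 `Cc1cccc(C2CC(c3ccc(C)c(C)c3)=NN2C2=NC(=O)CS2)c1` gives 237000 nM

Compound 1 has the lowest of the three numbers, yet its nearest neighbour compound 3 differs only by a 1.2-fold higher number from compound 1 to compound 3 (0.07 log units; within the scatter), and the numbers for compound 1 and compound 2 also lie within the usual scatter of each other. Compound 4 `Cc1ccccc1C1CC(c2ccc(Cl)c(Cl)c2)=NN1C1=NC(=O)CS1` differs from compound 1 as follows: 2-methylphenyl in place of 3-methylphenyl on a saturated ring carbon. Among the compounds with values here, the only step that touches the same saturated ring carbon, a 1.6-fold lower number from compound 2 to compound 3 (0.21 log units; within the scatter), was within the scatter, and the other step, a 1.2-fold higher number from compound 1 to compound 3 (0.07 log units; within the scatter), was likewise flat. No step beyond the scatter is therefore expected in this assay for this change. Compound 4 is estimated at 210000 nM (range 120000 nM to 370000 nM), meaning an expected step of a 1.0-fold higher number from compound 1 to compound 4 (0.01 log units; within the scatter).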

Compound 4, half-maximal cytotoxic concentration: 179000 nM
Compound 4: the middle estimate sits 1.2-fold (0.07 log units) above what was measured, within the range that was stated.
By their numbers in this assay, from the lowest: compounds 4, 1, 3 and 2 (each within the scatter of the next, the first and the last beyond it).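

In this assay, 2-methylphenyl in place of 3-methylphenyl on the saturated ring carbon gives a 1.1-fold lower number from compound 1 to compound 4 (0.06 log units; within the scatter). The earlier step at this carbon exchanged one substituted phenyl for another alongside 3,4-dimethylphenyl; this one keeps the same atoms, joined differently, alongside 3,4-dichlorophenyl, and it is also flat. No measurement at hand offers an explanation for this result. Still open, as far as these compounds go, is whether an amine or a carboxylic acid on this phenyl, or a longer chain in place of the methyl, would give a step beyond the scatter.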